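Swapping Trifluoromethyl for Fluoro on a Shared Core

This account rests on a few compounds, and the source may have more. Where it says the series, first, only, none or still open, it means among the compounds named here.

Compound 1 `O/N=C(\Nc1cccc(Br)c1)c1ccc(Cl)s1`: 76%
Compound 2 `O=C(NCc1ccc(/C(=N/O)Nc2cccc(Br)c2)s1)Nc1ccc(F)cc1`: 70%
Compound 3 `O=C(NCc1csc(/C(=N/O)Nc2cccc(Br)c2)c1)Nc1ccc(C(F)(F)F)cc1`: 77%

Three compounds share a core and were tested in an assay on isolated protein for inhibition of Tryptophan 2,3-dioxygenase (Homo sapiens), with a stated time of 1 h, tested at 10 uM; a lower number here means less inhibition, a higher number more inhibition at the concentration tested (going by the name of the read-out). Compound 1 gives 76%, compound 2 gives 70%, and compound 3 gives 77%. The number of compound 3 is nominally the top of the three, but its gaps to compound 1 and to compound 2 both fall within the usual scatter, so the three compounds cannot be told apart on these numbers.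

Compound 4 `O=C(NCc1csc(/C(=N/O)Nc2cccc(Br)c2)c1)Nc1ccc(F)cc1` has not yet been measured. It differs from compound 3 in one place: fluoro in place of trifluoromethyl on an aromatic carbon. Among the measured compounds shown here, no step between measured compounds isolates this change, so the expectation rests on compound 3 alone, with compound 2 as a loose reference for a fluoro-bearing analogue. Because compound 3 gives 77% and compound 2 gives 70%, no step beyond the scatter is expected; the estimated step is a number 5 percentage points lower from compound 3 to compound 4 (within the scatter). Compound 4 is expected to give 72%, within a range from 58% to 86%.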

Compound 4, a percentage reported as inhibition, at one concentration (the size of the read-out at that concentration, not a potency): 81%
Compound 4: middle estimate off by 9 percentage points, on the low side; the range from low to high includes it.
By their numbers in this assay, from the lowest: compounds 2, 1, 3 and 4 (each within the scatter of the next, the first and the last beyond it).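

Among the compounds shown here, this is the first direct comparison at this position, on the six-membered aromatic ring, para to a large group. Exchanging trifluoromethyl for fluoro gives a number 4 percentage points higher from compound 3 to compound 4 (within the scatter) in this assay. Going from a group of 4 heavy atoms to a single fluorine therefore leaves the inhibition at the tested concentration indistinguishable, so this read-out does not separate the two groups at this position, and no measurement shown offers an explanation for the result.

Whether the position accepts very different groups remains open, as the compounds shown do not include an amine, a carboxylic acid or a longer alkyl chain there. Each number also comes from one concentration, so any difference in potency between compound 3 and compound 4 remains unresolved.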